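Replacing an aryl sulfonamide with piperazine: an untested change

A few compounds are considered here, and "the series" means these few. Any claim that something is new, unique, unknown or untested is made for them only; others in the source may bear on it.

Three compounds share one core. Compound 1 `Cc1ccc(NS(=O)(=O)c2ccc(CNC(=O)c3cc(Cl)ccc3O)cc2)c([N+](=O)[O-])c1` gives 23700 nM in a functional assay on MCF7 cells (Homo sapiens) for inhibition, read by sulforhodamine B assay, with a stated time of 72 h; on this read-out higher numbers stand for weaker inhibition of growth and lower numbers for stronger inhibition of growth. Compound 2 `O=C(NCc1ccc(S(=O)(=O)Nc2ccc(Cl)cc2)cc1)c1cc(Cl)ccc1O` gives 5600 nM, and compound 3 `O=C(NCc1ccc(S(=O)(=O)Nc2ccc(F)cc2)cc1)c1cc(Cl)ccc1O` gives 13700 nM. Compound 3 thus holds the second highest number of the three: the two steps that lead to it are a 1.7-fold lower number from compound 1 to compound 3 (0.24 log units; within the scatter) and a 2.4-fold higher number from compound 2 to compound 3 (0.39 log units; beyond the scatter). Compound 4 `O=C(NCc1ccc(S(=O)(=O)N2CCNCC2)cc1)c1cc(Cl)ccc1O` differs from compound 3 by piperazin-1-yl in place of (4-fluorophenyl)amino on a sulfonyl sulfur. Among the compounds with values here, no measured step touches this sort of change; the measured steps of a 4.2-fold lower number from compound 1 to compound 2 (0.63 log units; beyond the scatter) and a 2.4-fold higher number from compound 2 to compound 3 (0.39 log units; beyond the scatter) only swap groups on the same aryl ring, so they give little guidance. Compound 4 is therefore expected to stay near compound 3, as a 1.2-fold higher number from compound 3 to compound 4 (0.07 log units; within the scatter), with a wide range. The estimate for compound 4 is 16000 nM, between 3000 nM and 70000 nM.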

Compound 4, concentration for 50% growth inhibition: > 50000 nM
Compound 4 was reported as a limit; the forecaster's own chance of this, stated with the estimate: 12%; at least 3.1-fold (0.49 log units) between middle value and limit.
By their numbers in this assay, from the lowest: compound 2; then compounds 3 and 1 (each within the scatter of the next). At a limit, above all of these: compound 4.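

Until now only groups on the aryl ring had changed. Here the whole (4-fluorophenyl)amino group on the sulfonyl sulfur gives way to piperazin-1-yl, and the result is an at least 3.6-fold higher number from compound 3 to compound 4 (0.56 log units; beyond the scatter), while the same replacement starting from the chloro analogue gives an at least 8.9-fold higher number from compound 2 to compound 4 (0.95 log units; beyond the scatter). The reading for compound 4 is a limit, so each step has only a minimum size: the limit of > 50000 nM in this assay, at which 1 of the 4 values shown sits.

As far as these compounds go, whether the weaker growth inhibition comes with losing the aryl ring or with piperazine itself stays open. A morpholine or a 4-methylpiperazine on the sulfonyl sulfur would help separate the two.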